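The source may hold more compounds than are shown below. What is called first, only, known or untested is meant among the compounds shown, and "the series" means these compounds.

Measured compounds:
compound 1 `O=C(Nc1ccc(Oc2ccnc3[nH]ccc23)cc1)c1cn(-c2ccc(Cl)cc2)c2ccccc2c1=O` with 650 nM
compound 2 `Cn1ccc2c(Oc3ccc(NC(=O)c4cn(-c5ccc(F)cc5)c5ccccc5c4=O)cc3F)ccnc21` with 1460 nM

In a functional assay on A549 cells (Homo sapiens) for inhibition, read by MTT assay, with a stated time of 72 h (on this read-out higher numbers stand for weaker inhibition and lower numbers for stronger inhibition), compound 2 gives 1460 nM, the highest of the two numbers. Compound 1 gives 650 nM, a lower number, and that gap lies beyond the scatter. Compound 3 `Cn1ccc2c(Oc3ccc(NC(=O)c4cn(-c5ccc(F)c(Cl)c5)c5ccccc5c4=O)cc3F)ccnc21` is compound 2 with a single change: chloro in place of hydrogen on an aromatic carbon. Among the measured compounds shown here, no measured pair shows this change, so the data give no step to lean on. The expected step of a 1.5-fold lower number from compound 2 to compound 3 (0.16 log units; within the scatter) from compound 2 to compound 3 is small, towards a lower number but not clearly beyond the scatter. Compound 3 is therefore estimated at 1000 nM, in a range from 400 nM to 2500 nM.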

Compound 3, half-maximal inhibitory concentration: 1210 nM
Beside the measured number, compound 3's estimate is 1.2-fold (0.08 log units) below it, within the range that was stated.
By their numbers in this assay, from the lowest: compounds 1, 3 and 2 (each within the scatter of the next, the first and the last beyond it).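

In this assay, the chloro group on the aromatic carbon ortho to the fluoro group, which turns 4-fluorophenyl into 3-chloro-4-fluorophenyl, comes with a 1.2-fold lower number from compound 2 to compound 3 (0.08 log units; within the scatter). Among the compounds shown here, this gives the first reading at this position: the ring accepts this one added chlorine with no step beyond the scatter. Nothing measured here explains why the step is so small. As far as these compounds go, whether a methoxy group, an amine or a carboxylic acid at this position would give a step beyond the scatter stays open. So does whether chloro would give a similar step on the core of compound 1.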